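From 2H-indazol-2-yl to 4-fluoro-1H-pyrazol-1-yl in compound 4

The source may hold more compounds than are shown below. What is called first, only, known or untested is meant among the compounds shown, and "the series" means these compounds.

In an ADME assay on microsomes from liver (Homo sapiens) for metabolic stability (on this read-out lower numbers stand for slow clearance and higher numbers for fast clearance), compound 1 `CCCC(Oc1ccc(-n2cc3ccccc3n2)cc1)c1ccc(C(=O)NCCC(=O)O)cc1` gives 44 mL/min/kg and compound 2 `O=C(O)CCNC(=O)c1ccc(C(Oc2ccc(-n3cc(C(F)(F)F)cn3)cc2)C2CCC2)cc1` gives 26 mL/min/kg while compound 3 `CC(C)(C)C(Oc1ccc(-n2cc(C(F)(F)F)cn2)cc1)c1ccc(C(=O)NCCC(=O)O)cc1` gives 31 mL/min/kg so that compound 1 stands within the scatter of both others.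

Compound 4 `CCCC(Oc1ccc(-n2cc(F)cn2)cc1)c1ccc(C(=O)NCCC(=O)O)cc1` keeps the core of compound 1 and carries 4-fluoro-1H-pyrazol-1-yl in place of 2H-indazol-2-yl on an aromatic carbon. Among the measured compounds shown here, no measured step covers this exchange. For the measured compounds named here, the one measured step of a 1.2-fold higher number from compound 2 to compound 3 (0.08 log units; within the scatter) stays within the scatter, but it lies on a saturated chain carbon and not at the place changed here, so it bears only loosely on compound 4.

A change beyond the scatter is therefore not expected in this assay. The expected step of a 1.4-fold lower number from compound 1 to compound 4 (0.14 log units; within the scatter) is estimated to remain within the scatter, with only a slight lean towards a lower number. The estimated value for compound 4 is 32 mL/min/kg (expected range 17 mL/min/kg to 55 mL/min/kg).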

Compound 4, clearance: 12 mL/min/kg
Estimate against measurement, compound 4: 2.7-fold (0.43 log units) above, outside the stated range (below it).
By their numbers in this assay, from the lowest: compound 4; then compounds 2, 3 and 1 (each within the scatter of the next).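

In this assay the exchange at this place, on an aromatic carbon para to a large group, gives a 3.7-fold lower number from compound 1 to compound 4 (0.56 log units; beyond the scatter) and so moves the read-out beyond the scatter, whereas a 1.2-fold higher number from compound 2 to compound 3 (0.08 log units; within the scatter) on the saturated chain carbon does not. The change takes out the six-membered aromatic ring of carbon only and brings in a fluorine in the same step, while the hydrogen-bond donor and acceptor counts stay as they were, so the step cannot be assigned to either part alone. Nothing measured here bears on the reason for the step. The compounds shown leave open how unsubstituted 1H-pyrazol-1-yl or 4-chloro-1H-pyrazol-1-yl would compare at this place on the core of compound 1. They also leave open whether 4-fluoro-1H-pyrazol-1-yl gives a similar step alongside the cyclobutyl or tert-butyl group.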